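Sulfonamide series against mitochondrial malate dehydrogenase: opening notes

This account rests on a few compounds, and the source may have more. Where it says the series, first, only, none or still open, it means among the compounds named here.

Compound 1 `O=S(=O)(Nc1ccc(-c2nc3ccccc3o2)cc1)c1cccc(O)c1`: in an assay on isolated protein for inhibition of malate dehydrogenase, mitochondrial (Sus scrofa), with stated times of 45 min and 30 min (on this read-out higher numbers stand for weaker inhibition and lower numbers for stronger inhibition), compound 1 gives only a limit, > 63000 nM.
Compound 2 `O=S(=O)(Nc1ccc2oc(-c3ccccc3)nc2c1)c1ccc(F)c(C(F)(F)F)c1`: in this assay compound 2 gives only a limit, > 63000 nM.
Compound 3 `O=S(=O)(Nc1ccc2oc(-c3ccccc3)nc2c1)c1ccc(Cl)cc1`: in this assay compound 3 gives only a limit, > 63000 nM.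

Compound 1 thus stands at the limit of this assay, with no number of its own, and every value shown so far sits at that same limit (the limit of > 63000 nM in this assay, at which 3 of the 3 values shown sit). Going by the values given here, no pair of measured compounds differs in a single place, so no step can be read from the data.

Compound 4 `O=S(=O)(Nc1ccc(-c2nc3ccccc3o2)cc1)c1ccccc1F` is not yet measured. It differs from compound 1 by 2-fluorophenyl in place of 3-hydroxyphenyl on a sulfonyl sulfur. With nothing measured in the series beyond limits, the step is estimated to be a step that the limit leaves unreadable from compound 1 to compound 4, which would be none beyond the scatter. Compound 4 is estimated at 100000 nM, within 30000 nM to 400000 nM, and most probably returns only a limit again.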

Compound 4, half-maximal inhibitory concentration: > 63000 nM
Compound 4 gave a limit, no number; the forecaster's own chance of this, stated with the estimate: 80%; the middle value is on the limit's open side.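

Compound 1 and compound 4 both return only limits in this assay, so no step can be read between them: the limit of > 63000 nM in this assay, at which 4 of the 4 values shown sit. The compounds shown leave open whether any change at the sulfonyl sulfur or in the shared core gives a value inside the assay's range.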